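Fluorine added twice to the phenyl of compound 1

The compounds below may be only part of what the source reports. "The series", "measured", "known", "first", "only" and "open" are said of these compounds alone.

Of the compounds shown here, two sharing one core have been tested. In a functional assay on HEK293 cells with D(4) dopamine receptor (Homo sapiens) as the target, read by FLIPR (a higher number here means that more compound is needed for the effect, a lower number that less compound is needed), compound 1 `O/N=C(/CCN1CCN(c2ccccn2)CC1)c1ccccc1` gives 21.7 nM, and compound 2 `O/N=C(\CCN1CCN(c2ccccn2)CC1)c1cccc(F)c1` gives 17.1 nM in this assay. The gap between these two numbers lies within the usual scatter of repeated measurements, so compound 1 stands side by side with compound 2 rather than apart from it.

Compound 3 `O/N=C(/CCN1CCN(c2ccccn2)CC1)c1cc(F)cc(F)c1` has not yet been measured. It differs from compound 1 in one place: 3,5-difluorophenyl in place of phenyl on a carbon with a double bond to nitrogen. Going by the values given here, no step between measured compounds of exactly this kind is available, so the expected size of the step in this assay is drawn only from how close compound 1 and compound 2 sit. On that basis the step from compound 1 to compound 3 is expected to be small, at most a modest move towards a lower number, a 1.4-fold lower number from compound 1 to compound 3 (0.16 log units; within the scatter). Compound 3 is therefore estimated to give 15 nM in this assay, with a plausible range from 6 nM to 40 nM.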

Compound 3, half-maximal effective concentration: 17.5 nM
The estimate for compound 3 lay 1.2-fold (0.07 log units) below the measured number, within the range that was stated.
By their numbers in this assay, from the lowest: compounds 2, 3 and 1 (each within the scatter of the next).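

Putting 3,5-difluorophenyl in place of phenyl on the carbon with a double bond to nitrogen gives a 1.2-fold lower number from compound 1 to compound 3 (0.09 log units; within the scatter) in this assay. This is the first step shown that changes one place only, and it shows that the aromatic ring at this position can carry two fluorine atoms, growing from 6 to 8 heavy atoms, with no change beyond the scatter of this read-out. Nothing on hand explains why the number holds steady here.

Still open, on these data alone, is whether this position accepts groups of a different kind on the ring, such as methoxy, an amine or a carboxylic acid, as readily as it accepts fluorine. Also open, as far as these compounds go, is how compound 3 behaves at any receptor other than this one.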